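Working notes: bromo in place of nitro on a shared core

The source may hold more compounds than are shown below. What is called first, only, known or untested is meant among the compounds shown, and "the series" means these compounds.

Compound 1 `COc1cc(OC)c2c(=O)cc(/C=C/c3ccc([N+](=O)[O-])cc3)oc2c1` is the reference of the set. In a functional assay on A549 cells (Homo sapiens) for antiproliferative activity, read by MTT assay, with a stated time of 12 h (on this read-out lower numbers stand for stronger inhibition and higher numbers for weaker inhibition), compound 1 gives 19700 nM, the highest of the two numbers shown; compound 2 `COc1cc(OC)c2c(=O)cc(/C=C/c3ccc(F)cc3)oc2c1` gives 18600 nM, and the step of a 1.1-fold lower number from compound 1 to compound 2 (0.02 log units; within the scatter) is within the scatter, so no order between these two is claimed. Compound 3 `COc1ccc(/C=C/c2cc(=O)c3c(OC)cc(OC)cc3o2)cc1` is reported in this assay only as a limit of the assay, > 40000 nM. That limit is noted as the limit of > 40000 nM in this assay, at which 1 of the 3 values shown sits. The steps of an at least 2.0-fold higher number from compound 1 to compound 3 (0.30 log units; that floor lies within the scatter) and an at least 2.1-fold higher number from compound 2 to compound 3 (0.33 log units; beyond the scatter) both run toward that limit.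

Compound 4 `COc1cc(OC)c2c(=O)cc(/C=C/c3ccc(Br)cc3)oc2c1` differs from compound 1 by bromo in place of nitro on an aromatic carbon. The nearest measured step is the fluoro for nitro change, a 1.1-fold lower number from compound 1 to compound 2 (0.02 log units; within the scatter), which stayed within the scatter; the methoxy steps point upward but end at a limit and do not bear directly on bromo. The expected step in this assay is therefore none beyond the scatter, a 1.1-fold lower number from compound 1 to compound 4 (0.04 log units; within the scatter). Compound 4 is estimated at 18000 nM, with a range of 8000 nM to 40000 nM.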

Compound 4, half-maximal inhibitory concentration: > 40000 nM
Compound 4 gave a limit, no number; the forecaster's own chance of this, stated with the estimate: 15%; middle value at least 2.2-fold (0.34 log units) from the limit.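

Compound 4 is reported in this assay only as a limit, not a number, which places bromo with methoxy rather than with fluoro and nitro: the limit of > 40000 nM in this assay, at which 2 of the 4 values shown sit. Bromo in place of fluoro gives an at least 2.1-fold higher number from compound 2 to compound 4 (0.33 log units; beyond the scatter), so exchanging one halogen for another at this place, on an aromatic carbon para to a large group, is enough to separate two compounds on the shared core. Against the reference the step is an at least 2.0-fold higher number from compound 1 to compound 4 (0.30 log units; that floor lies within the scatter), and the step between compound 3 and compound 4 cannot be read, as both values are limits.

From the compounds shown here alone, how far compound 3 and compound 4 lie beyond the limit stays open, so bromo and methoxy cannot be ordered. Going by these compounds, whether chloro, an amine or a carboxylic acid at this place would give a number or a limit also stays open.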